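Adding a methoxy group to compound 1

The source may report more compounds than this note shows. Statements on the series, on what has been measured and on what is new or still open speak of the compounds shown alone.

- compound 1 `NC(=O)c1ccccc1NC(=O)COc1ccccc1` gives 523000 nM
- compound 2 `NC(=O)c1cc(Cl)ccc1NC(=O)COc1ccccc1` gives 808000 nM
- compound 3 `Cc1ccc(OCC(=O)Nc2ccc(I)cc2C(N)=O)cc1` gives 356000 nM

These numbers come from an ADME assay on HuDe cells (Homo sapiens) for cytotoxicity, read by MTT assay, with a stated time of 72 h (on this read-out higher numbers stand for weaker inhibition and lower numbers for stronger inhibition), and compound 1 lies within the usual scatter of both compound 2 and compound 3. Compound 4 `COc1ccc(NC(=O)COc2ccccc2)c(C(N)=O)c1` has not been measured yet. Its difference from compound 1 is methoxy in place of hydrogen on an aromatic carbon and in words this is methoxy in place of hydrogen on an aromatic carbon. Among the compounds with values here, the one measured step at a single place is a 1.5-fold higher number from compound 1 to compound 2 (0.19 log units; within the scatter) and it puts chloro in place of hydrogen on an aromatic carbon, staying within the scatter. No clear step in either direction is therefore expected in this assay for the methoxy change. The estimated step is a 1.1-fold higher number from compound 1 to compound 4 (0.02 log units; within the scatter) and stays within the scatter. Compound 4 is estimated at 550000 nM with an expected range from 280000 nM to 1000000 nM for that value.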

Compound 4, half-maximal inhibitory concentration: 942000 nM
Estimate against measurement, compound 4: 1.7-fold (0.23 log units) below; measured number inside the range.
By their numbers in this assay, from the lowest: compounds 3, 1, 2 and 4 (each within the scatter of the next, the first and the last beyond it).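

In this assay, methoxy on this aromatic carbon, para to a large group and meta to a carbamoyl group, gives a 1.8-fold higher number from compound 1 to compound 4 (0.26 log units; within the scatter) and so makes no clear difference. Putting methoxy in place of chloro on that same carbon gives a 1.2-fold higher number from compound 2 to compound 4 (0.07 log units; within the scatter) and so does not separate the two groups either. No measurement on hand accounts for these numbers.

Still open, as far as these compounds go, is whether an amine or a carboxylic acid on this carbon would shift the number beyond the scatter. Also open, from the compounds shown here alone, is whether methoxy would behave the same way on another carbon of this ring.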